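Benzyl in place of ethyl on a second quinone core

The compounds below may be only part of what the source reports. "The series", "measured", "known", "first", "only" and "open" are said of these compounds alone.

Measured so far in a functional assay on NCI-H460 cells (Homo sapiens) for cytotoxicity, read by MTT assay, with a stated time of 72 h; a lower number here means a stronger inhibitor, a higher number a weaker inhibitor:
compound 1, `CC(C)(C)C1=CC(=O)C=C(NCc2ccccc2)C1=O`, 14000 nM
compound 2, `CCNC1=CC(=O)C=C(C(C)(C)C)C1=O`, 13000 nM
compound 3, `CCNC1=CC(=O)C(C(C)(C)C)=CC1=O`, 64000 nM

Compound 3 stands apart: its number lies beyond the scatter from both compound 1 and compound 2. Compound 3 and compound 2 are built from the same atoms joined differently; the difference between the two cores is not broken down here.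

The change phenyl in place of methyl on a saturated chain carbon bound to an amine nitrogen gave a 1.1-fold higher number from compound 2 to compound 1 (0.03 log units; within the scatter). Compound 4, `CC(C)(C)C1=CC(=O)C(NCc2ccccc2)=CC1=O`, carries the same change, (phenyl in place of methyl on a saturated chain carbon bound to an amine nitrogen), made on the core of compound 3. Since that change left the number essentially unmoved between compound 2 and compound 1, compound 4 is expected to stay close to compound 3, with an estimated step of a 1.1-fold higher number from compound 3 to compound 4 (0.04 log units; within the scatter). The estimate for compound 4 in this assay is 70000 nM, expected between 35000 nM and 140000 nM.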

Compound 4, half-maximal inhibitory concentration: 19000 nM
Beside the measured number, compound 4's estimate is 3.7-fold (0.57 log units) above it; measured number below the stated range.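

In this assay the change of methyl to phenyl gave a 3.4-fold lower number from compound 3 to compound 4 (0.53 log units; beyond the scatter) on the core of compound 3, so the near-absence of a step on the other core did not carry over. The two steps differ: the same change on two cores in this assay, a 1.1-fold higher number (0.03 log units; within the scatter) from compound 2 to compound 1 and a 3.4-fold lower number (0.53 log units; beyond the scatter) from compound 3 to compound 4, 3.6-fold (0.56 log units) apart, beyond the scatter of two such steps. This rests on one pair of compounds per core, so it shows that the size of this step depends on the core here, but not what in the cores sets it apart, nor whether other changes would behave the same way.

The compounds shown leave open how a longer chain on the amine nitrogen would fare on either core. They also leave open whether a carboxylic acid or an amine at the end of that chain would separate the two cores in the same way.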